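This account rests on a few compounds, and the source may have more. Where it says the series, first, only, none or still open, it means among the compounds named here.

Working notes on the series.

Three compounds of this set have been run in a functional assay on DU-145 cells (Homo sapiens) for inhibition, read by trypan blue exclusion, with a stated time of 96 h; a lower number here means a stronger inhibitor of growth, a higher number a weaker inhibitor of growth. Compound 1 `O=C(/C(=C\c1ccc(Br)cc1)SCc1ccc(Cl)cc1)c1ccc(Br)cc1` gives 1000 nM in this assay. Compound 2 `COc1ccc(C(=O)/C(=C\c2ccc(OC)c(O)c2)Sc2ccc(F)cc2)cc1` gives 1000 nM in this assay. Compound 3 `COc1ccc(/C=C(/SCc2ccc(Cl)cc2)C(=O)c2ccc(Br)cc2)cc1O` gives 1000 nM in this assay. The three values lie within the usual scatter of one another, so no order among them can be read from these digits.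

One single-point change is documented within the measured compounds. From compound 3 to compound 1 the change is 4-bromophenyl in place of 3-hydroxy-4-methoxyphenyl on a double-bonded chain carbon bound to a double-bonded chain carbon, and the step was no change at the digits printed from compound 3 to compound 1 (within the scatter). Compound 2 and compound 3 differ in more than one place; the difference between the two cores is not broken down here, and their values in this assay simply sit level.

Compound 4 `COc1ccc(C(=O)/C(=C\c2ccc(Br)cc2)Sc2ccc(F)cc2)cc1` has not yet been measured. It differs from compound 2 by 4-bromophenyl in place of 3-hydroxy-4-methoxyphenyl on a double-bonded chain carbon bound to a double-bonded chain carbon, which is the same change, at the same place, as was made from compound 3 to compound 1. The remainder of the molecule is not the same in the two pairs, and the data give no second instance of the change on the core of compound 2. Resting on compound 3 to compound 1 having shown no change at the digits printed from compound 3 to compound 1 (within the scatter), the step from compound 2 to compound 4 is expected to be no change at the digits printed from compound 2 to compound 4 (within the scatter). Compound 4 is therefore estimated to give 1000 nM in this assay, with an expected range from 500 nM to 2000 nM.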

Compound 4, concentration for 50% growth inhibition: > 100000 nM
Compound 4: only a limit was reported; the forecaster's own chance of this, stated with the estimate: 20%; middle value at least 100-fold (2.00 log units) away from the limit.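

The change to 4-bromophenyl in place of 3-hydroxy-4-methoxyphenyl gives an at least 100-fold higher number from compound 2 to compound 4 (2.00 log units; beyond the scatter) in this assay, so the outcome of this change on one core does not carry over to the other: the same change on two cores in this assay, no change at the digits printed (within the scatter) from compound 3 to compound 1 and an at least 100-fold higher number (2.00 log units; beyond the scatter) from compound 2 to compound 4, at least 100-fold (2.00 log units) apart, beyond the scatter of two such steps

Compound 4 gives > 100000 nM, which is a limit of the assay and not a number, so the full size of the step cannot be read from it: the limit of > 100000 nM in this assay, at which 1 of the 4 values shown sits.

The two pairs show that the outcome of the change depends on the core, but they do not show which of the differences between the two cores is responsible, and they give no cause for the gap.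

The compounds shown leave open whether the result on the second core follows from the loss of the hydroxy group, the loss of the methoxy group or the entry of bromine, as only 3-hydroxy-4-methoxyphenyl and 4-bromophenyl are compared at this place. Also open, going by these compounds, is how a phenyl ring carrying a single hydroxy group, a single methoxy group or an amine would behave at this place on either core.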